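Ethyl for Methyl on the Anilino Ring

The compounds below may be only part of what the source reports. "The series", "measured", "known", "first", "only" and "open" are said of these compounds alone.

Two analogues sharing one core have been measured. Compound 1 `COc1cc2ncnc(Nc3cccc(Cl)c3)c2cc1OCCCCC(=O)Nc1ccc(S(N)(=O)=O)cc1` gives 11200 nM in a functional assay on A549 cells (Homo sapiens) for antiproliferative activity, read by MTT assay, with a stated time of 72 h; on this read-out lower numbers stand for stronger inhibition and higher numbers for weaker inhibition. Compound 2 `COc1cc2ncnc(Nc3cccc(C)c3)c2cc1OCCCCC(=O)Nc1ccc(S(N)(=O)=O)cc1` gives 16000 nM in this assay. Within the data shown here, the one step between them, a 1.4-fold higher number from compound 1 to compound 2 (0.15 log units; within the scatter), involved exchanging methyl for chloro on an aromatic carbon, and it did not rise above the scatter. Compound 2 thus stands at the higher of the two numbers, with compound 1 as its nearest neighbour and no real separation between them.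

Compound 3 `CCc1ccc(Nc2ncnc3cc(OC)c(OCCCCC(=O)Nc4ccc(S(N)(=O)=O)cc4)cc23)cc1` is the next member: 4-ethylphenyl in place of 3-methylphenyl on a nitrogen on an aromatic ring. Among the measured compounds shown here, no measured step concerns an ethyl group or a change in where a substituent sits on that ring, so the only guidance is that the single recorded alteration of this ring, from compound 1 to compound 2, left the number essentially unchanged. Given that, compound 3 is expected to land close to compound 2, with a step of a 1.1-fold higher number from compound 2 to compound 3 (0.05 log units; within the scatter) that is expected to stay within the scatter. Compound 3 is therefore estimated at 18000 nM, with a range from 7000 nM to 45000 nM.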

Compound 3, half-maximal inhibitory concentration: 12100 nM
Beside the measured number, compound 3's estimate is 1.5-fold (0.17 log units) above it, within the range that was stated.
By their numbers in this assay, from the lowest: compounds 1, 3 and 2 (each within the scatter of the next).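

In this assay, replacing 3-methylphenyl with 4-ethylphenyl on a nitrogen on an aromatic ring gives a 1.3-fold lower number from compound 2 to compound 3 (0.12 log units; within the scatter), and replacing 3-chlorophenyl with the same group gives a 1.1-fold higher number from compound 1 to compound 3 (0.03 log units; within the scatter), so neither step rises above the scatter. The earlier pair had varied only the methyl and chloro groups on a 3-substituted phenyl, whereas these steps show that a phenyl group with one more carbon and a differently numbered substituent also stays within the scatter, leaving all three compounds inseparable on this read-out. No measurement offered here accounts for this result, and the numbers alone cannot say why these groups are indistinguishable.

Because the step from compound 2 to compound 3 alters both the substituent and its ring position, the compounds shown cannot separate those two changes, which a pair such as 3-ethylphenyl and 4-methylphenyl would begin to address. Going by these compounds, it also remains open whether a markedly different substituent on this phenyl ring, such as an amine or a carboxylic acid, or a longer chain at the para-free ethyl site's place, would move the number beyond the scatter.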